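Adding a chloro group to compound 1's benzyl

A few compounds are considered here, and "the series" means these few. Any claim that something is new, unique, unknown or untested is made for them only; others in the source may bear on it.

Compound 1 `CCCCc1[nH]c(=O)c(-c2nnc(Cc3ccccc3)o2)c(O)c1-c1c(OC)cccc1OC` in an ADME assay on microsomes from liver (Homo sapiens) for metabolic stability, read by mass spectrometry, using NADPH, with a stated time of 10 min (a higher number here means that more of the compound is left, a lower number that less of the compound is left), gives 87%
Compound 2 `CCCCc1[nH]c(=O)c(-c2nc(Cc3ccccc3)no2)c(O)c1-c1c(OC)cccc1OC` in this assay gives 69%

Of these two measured compounds, compound 1 stands highest at 87%, while compound 2 at 69% lies lower by more than the usual scatter. Compound 3 `CCCCc1[nH]c(=O)c(-c2nnc(Cc3ccc(Cl)cc3)o2)c(O)c1-c1c(OC)cccc1OC` has not yet been measured in this assay. It keeps the core of compound 1 and differs from it in one place: chloro in place of hydrogen on an aromatic carbon. This is chloro in place of hydrogen on an aromatic carbon, para to a large group, turning benzyl into 4-chlorobenzyl. Going by the values given here, no measured pair shows what this change does, so the expectation starts from compound 1 at 87%. The expected step of a number 5 percentage points lower from compound 1 to compound 3 (within the scatter) is a small fall that stays within the scatter. For compound 3 the estimated value is 82%, with an expected range from 68% to 93%.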

Compound 3, percent of the compound remaining: 66%
For compound 3 the middle estimate is 16 percentage points above the measured one; measured number outside the range, below it.
By their numbers in this assay, from the lowest: compounds 3 and 2 (each within the scatter of the next); then compound 1.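

Turning benzyl into 4-chlorobenzyl gives the first reading of this position: in this assay the change produces a number 21 percentage points lower from compound 1 to compound 3 (beyond the scatter), so the percent of the compound remaining is sensitive to substitution here. A single chlorine atom on an aromatic carbon, para to a large group, is enough to move the read-out beyond the usual scatter. Nothing among the data shown explains this fall.

This single pair cannot show whether the fall belongs to chloro itself or would follow any group placed there, and a fluoro or a methoxy group at the same place would separate those two readings. It also leaves open whether the same change would have a similar effect on compound 2, whose benzyl still carries only hydrogen there.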